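This account rests on a few compounds, and the source may have more. Where it says the series, first, only, none or still open, it means among the compounds named here.

Compound 1 `CC(Sc1nnc(-c2ccncc2)s1)C(=O)NCc1ccc(Cl)cc1` carries no result in an ADME assay on BHK-21 cells (Mesocricetus auratus) for cytotoxicity, with a stated time of 3 days (a lower number here means that less compound is tolerated, a higher number that more compound is tolerated), its entry reading "not determined" (no result reported). Compound 2 `O=C(CCSc1nnc(-c2ccncc2)s1)Nc1ccccc1` is reported in this assay as > 50000 nM, which is a limit of the assay and not a number. Compound 3 `CC(CSc1nnc(-c2ccncc2)s1)C(=O)Nc1ccccc1Cl` likewise reaches only a limit in this assay, reported as > 50000 nM. Compound 3 thus stands where the measured part of the set stands, at the limit of > 50000 nM in this assay, at which 2 of the 3 values shown sit, with one further compound lacking any number at all. Compound 4 `CC(CSc1nnc(-c2ccncc2)s1)C(=O)Nc1ccc(Cl)cc1` differs from compound 3 by 4-chlorophenyl in place of 2-chlorophenyl on an amide-type nitrogen. Within the data shown here, no pair of measured compounds differing in a single place is available, so nothing measured speaks to the size of this step. The change is expected to produce no step beyond the usual scatter in this assay, in either direction, and the expected step from compound 3 to compound 4 is a number no higher from compound 3 to compound 4 (the limit leaves the size open). For compound 4 the estimated value in this assay is 50000 nM, with a range from 20000 nM to 100000 nM, and it is expected to be reported again only as a limit.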

Compound 4, half-maximal cytotoxic concentration: > 50000 nM
Compound 4: a limit, no number; the forecaster's own chance of this, stated with the estimate: 80%; the middle value sits exactly at the limit.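

Compound 4 is reported in this assay as > 50000 nM, a limit of the assay and not a number. Compound 3 also sits at a limit, so no step can be read between compound 3 and compound 4. Where either compound truly lies stays open, and with it whether 4-chlorophenyl and 2-chlorophenyl differ in this assay at all.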